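The source may hold more compounds than are shown below. What is called first, only, known or untested is meant among the compounds shown, and "the series" means these compounds.

Measured so far in a functional assay on A549 cells (Homo sapiens) for antiproliferative activity, read by sulforhodamine B assay, with a stated time of 48 h; on this read-out lower numbers stand for stronger inhibition and higher numbers for weaker inhibition:
Compound 1 `COc1ccc(C[C@@H](O)/C=C/C=C/C(=O)N2CCCCC2)cc1OC` gives 16400 nM
Compound 2 `COc1ccc(C[C@@H](O)/C=C/C=C/C(=O)N2CCN(C)CC2)cc1OC` gives 22200 nM
Compound 3 `COc1ccc(C[C@@H](O)/C=C/C=C/C(=O)NCc2ccccc2)cc1OC` gives 17100 nM

Compound 2 stands within the usual scatter of both compound 1 and compound 3, so these three numbers cannot be told apart. The next compound to be tested, compound 4 `COc1ccc(C[C@@H](O)/C=C/C=C/C(=O)N2CCN(c3ccccn3)CC2)cc1OC`, keeps the shared core of compound 2 and carries pyridin-2-yl in place of methyl on an amine nitrogen in a ring.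

Among the measured compounds shown here, no measured step makes this exact swap, so the evidence is indirect. The nearest guide comes from three changes to the group on the carbonyl carbon: a 1.4-fold higher number from compound 1 to compound 2 (0.13 log units; within the scatter), a 1.0-fold higher number from compound 1 to compound 3 (0.02 log units; within the scatter) and a 1.3-fold lower number from compound 2 to compound 3 (0.11 log units; within the scatter). All three lie within the scatter, and one of them brings in the benzylamino group with its own ring. On that basis, no change beyond the scatter is expected, though the range must stay wide for a group not yet tested here. The step expected in this assay is a 1.3-fold lower number from compound 2 to compound 4 (0.12 log units; within the scatter). Compound 4 is estimated at 17000 nM, with an expected range from 7000 nM to 35000 nM.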

Compound 4, half-maximal inhibitory concentration: 8130 nM
Compound 4: the middle estimate sits 2.1-fold (0.32 log units) above what was measured; the range from low to high includes it.
By their numbers in this assay, from the lowest: compounds 4, 1, 3 and 2 (each within the scatter of the next, the first and the last beyond it).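

Among the compounds shown here, replacing methyl with pyridin-2-yl on the amine nitrogen in the ring gives, in this assay, a 2.7-fold lower number from compound 2 to compound 4 (0.44 log units; beyond the scatter), the first step in this set that lies beyond the scatter. The earlier steps all swapped the whole group on the carbonyl carbon and all stayed within the scatter, so this outer position is the first place shown where a single change moves the number, if only modestly. No measurement shown accounts for this step.

On these data alone, it remains open whether the ring itself or its nitrogen matters, which phenyl on the same amine nitrogen would help to separate, while pyridin-3-yl and pyridin-4-yl would test whether the place of that nitrogen in the ring counts. A benzyl group there would show whether the ring tolerates a carbon spacer.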